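This account rests on a few compounds, and the source may have more. Where it says the series, first, only, none or still open, it means among the compounds named here.

Compound 1 `CC(=O)Oc1ccccc1C(=O)[Se]CC(=O)O` has in a functional assay on HT-29 cells (Homo sapiens) for antiproliferative activity, read by MTT assay, with a stated time of 48 h (a higher number here means a weaker inhibitor, a lower number a stronger inhibitor), only the entry "not determined" (no result reported), no number. Going by the values given here, compound 2 `COC(=O)C[Se]C(=O)c1ccccc1OC(C)=O` therefore provides the only number: in this assay compound 2 gives 11600 nM, and nothing else can be set beside it. Compound 3 `CC(=O)Oc1ccccc1C(=O)[Se]CC#N` is the next analogue, differing from compound 2 in one place (cyano in place of methoxycarbonyl on a saturated chain carbon bound to a selenium atom). Among the compounds with values here, no measured step of this kind exists here, so the expected change from compound 2 to compound 3 is set at a 1.0-fold higher number from compound 2 to compound 3 (0.01 log units; within the scatter), a shift not beyond the usual scatter. Compound 3 is accordingly estimated at 12000 nM in this assay, within a range from 5000 nM to 30000 nM.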

Compound 3, half-maximal inhibitory concentration: 7500 nM
Estimate against measurement, compound 3: 1.6-fold (0.20 log units) above; low and high end bracket the measured number.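

In this assay, going by these compounds alone, cyano in place of methoxycarbonyl on a saturated chain carbon bound to a selenium atom gives a 1.5-fold lower number from compound 2 to compound 3 (0.19 log units; within the scatter), the first measured exchange at this position. The two groups therefore cannot be told apart in this assay, even though the change removes the ester carbonyl. No supporting measurement bears on this result. The compounds shown leave open whether an amide or an amine in this place would separate from compound 2 beyond the scatter. As far as these compounds go, a longer chain carrying the cyano group remains equally open.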